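Cyclopropane amide series: aryl-to-cyclohexyl swap on the cyclopropane

The source may hold more compounds than are shown below. What is called first, only, known or untested is meant among the compounds shown, and "the series" means these compounds.

Compound 2 `CC[C@H](C)[C@H](N)CN(C(=O)[C@@H]1C[C@H]1c1cccc(OC)c1)c1ccc(-c2ccccc2)cc1` carries the highest of the two numbers recorded in a functional assay for agonist activity at G protein-coupled receptor 88 (Homo sapiens), read by HTRF and cAMP accumulation; on this read-out higher numbers stand for an effect only at larger amounts of compound and lower numbers for an effect already at smaller amounts: compound 2 gives 3000 nM. Its nearest neighbour is compound 1 `CCC(C)CNCCN(C(=O)[C@@H]1C[C@H]1c1ccccc1)c1ccc(-c2ccccc2)cc1`, which differs in several places at once and in this assay gives 4.7 nM, a far lower number that lies beyond the scatter. No single-point comparison exists between these two compounds, so nothing in the set isolates the contribution of the aryl group on the cyclopropane.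

Compound 3 `CC[C@H](C)[C@H](N)CN(C(=O)[C@@H]1C[C@H]1C1CCCCC1)c1ccc(-c2ccccc2)cc1` is the next member to be run in this assay. It differs from compound 2 by cyclohexyl in place of 3-methoxyphenyl on a saturated ring carbon of the three-membered ring. For the measured compounds named here, with no measured step of this kind available, the expectation rests on compound 2 alone, and a step of modest size in the weaker direction, possibly none beyond the scatter, is expected for a 1.7-fold higher number from compound 2 to compound 3 (0.22 log units; within the scatter). Compound 3 is accordingly estimated at 5000 nM, within a range of 1000 nM to 25000 nM.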

Compound 3, half-maximal effective concentration: > 25000 nM
Compound 3 was reported as a limit; the forecaster's own chance of this, stated with the estimate: 30%; at least 5.0-fold (0.69 log units) between middle value and limit.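

Compound 3 in this assay gives > 25000 nM, which is a limit of the assay and not a number: the limit of > 25000 nM in this assay, at which 1 of the 3 values shown sits.

For the compounds shown here, this pair supplies the first comparison in the set that differs in one place, and it reads as an at least 8.3-fold higher number from compound 2 to compound 3 (0.92 log units; beyond the scatter). At this saturated ring carbon of the three-membered ring, cyclohexyl is therefore not interchangeable with 3-methoxyphenyl in this assay, at least for this pair and this amine side chain.

The change removes the methoxy oxygen and the aromatic ring together, so the compounds shown do not tell which of the two matters. Also open, on these data alone, is how a pyridyl ring or a 3-methoxycyclohexyl group would read at the same place.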